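The compounds below may be only part of what the source reports. "The series", "measured", "known", "first", "only" and "open" are said of these compounds alone.

Measured so far in a physicochemical assay for lipophilicity, read by mass spectrometry; a lower number here means a more polar compound, a higher number a more lipophilic compound:
- compound 1 `CCOc1ccc(NC(=O)C2Cc3cc(OC)c(OC)cc3C2=O)cc1` gives 2.42
- compound 2 `COc1cc2c(cc1OC)C(=O)C(C(=O)Nc1ccc(Br)cc1)C2` gives 3.03

Compound 2 holds the higher of these two numbers. Among the measured compounds shown here, the only measured step is a number 0.61 log units higher from compound 1 to compound 2 (beyond the scatter), with bromo in place of ethoxy on an aromatic carbon.

Compound 3 `COc1cc2c(cc1OC)C(=O)C(C(=O)Nc1cccc(Cl)c1)C2` is not yet measured. Its difference from compound 2 is 3-chlorophenyl in place of 4-bromophenyl on an amide-type nitrogen.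

For the measured compounds named here, no measured step exchanges bromo for chloro, and none changes where a halogen stands. The step of a number 0.61 log units higher from compound 1 to compound 2 (beyond the scatter) therefore bears only loosely, as it replaced ethoxy and not one halogen-bearing group with another. A small downward move in this assay is expected, not clearly beyond the scatter. The estimated step is a number 0.13 log units lower from compound 2 to compound 3 (within the scatter) and rests on little data. For compound 3 the expected value is 2.9 and the estimated range runs from 2.55 to 3.25.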

Compound 3, partition coefficient: 2.76
Compound 3: the middle estimate sits 0.14 log units above what was measured, within the range that was stated.
By their numbers in this assay, from the lowest: compound 1; then compounds 3 and 2 (each within the scatter of the next).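

In this assay, 3-chlorophenyl in place of 4-bromophenyl on an amide-type nitrogen gives a number 0.27 log units lower from compound 2 to compound 3 (within the scatter) and so leaves compound 2 and compound 3 not distinguishable in this assay. Among the compounds shown here, this is the only measured step that exchanges one halogen-bearing phenyl for another, and the earlier step from an ethoxy-bearing compound offered no such comparison. No measurement is available that bears on a cause for this result.

The halogen and its place on the phenyl differ together in this single step, so the compounds shown cannot separate one from the other. Also open, on these data alone, is how this assay reads when a carboxylic acid or an amine stands on this phenyl in place of the halogen.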